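This account rests on a few compounds, and the source may have more. Where it says the series, first, only, none or still open, it means among the compounds named here.

Measured compounds:
- compound 1, `C/C=C(\CC)Oc1cc(C)nc(Oc2c(C)cc(C)cc2C)c1C`: 55%
- compound 2, `CCC(CC)Oc1cc(C)nc(Oc2c(C)cc(C)cc2C)c1N`: 51%
- compound 3, `CCCc1cc(C)c(Oc2nc(C)cc(OC(CC)CC)c2C)c(C)c1`: 34%

The read-out is a functional assay on the whole organism for displacement of a labelled ligand, with Rattus norvegicus as the target, at a dose of 3.2 mg/kg by the subcutaneous route; on this read-out higher numbers stand for more inhibition at the one dose given (going by the name of the read-out) and lower numbers for less inhibition. On the three numbers shown, compound 1 gives the highest figure; the number for compound 2 lies close to it, and the two cannot be told apart within the usual scatter. Compound 3 sits a good deal lower, and that gap is beyond the scatter. Among the compounds with values here, no pair among the measured compounds differs in a single place, so no measured step is available to guide the next change.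

Compound 4, `CCC(COC)Oc1cc(C)nc(Oc2c(C)cc(C)cc2C)c1C`, is compound 1 with one change: 1-(methoxymethyl)propyl in place of 1-ethylprop-1-en-1-yl on an oxygen on an aromatic ring. Nothing in the measured set isolates this kind of exchange on the aryl ether oxygen, so the expectation rests on the spread of the three numbers alone. A step from compound 1 to compound 4 of a number 8 percentage points lower from compound 1 to compound 4 (within the scatter) is expected, that is, no movement clearly beyond the scatter, with a slight lean downward. Compound 4 is estimated at 47% in this assay, with a range from 25% to 65%.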

Compound 4, a percentage reported as inhibition, in the whole organism at one dose (the size of the read-out at that dose, not a potency): 49%
Compound 4: the middle estimate sits 2 percentage points below what was measured, and the stated range covers the measured number.
By their numbers in this assay, from the lowest: compound 3; then compounds 4, 2 and 1 (each within the scatter of the next).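

In this assay, within the data shown here, 1-(methoxymethyl)propyl in place of 1-ethylprop-1-en-1-yl on an oxygen on an aromatic ring gives the first single-place step, a number 6 percentage points lower from compound 1 to compound 4 (within the scatter). On this oxygen, the read-out therefore stays within the scatter when a group with 5 heavy atoms and 1 double bond outside aromatic rings gives way to one with 6 heavy atoms, no such double bond and 1 hydrogen-bond acceptor. No supporting measurement bears on the reason for this outcome.

A single step sets no trend for this position, so the exchange may not hold for other groups on this oxygen. Still open, from the compounds shown here alone, is how the read-out responds to a 1-(hydroxymethyl)propyl group, a 1-(aminomethyl)propyl group or a longer ether chain in the same place.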